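Methoxy for fluoro on two related cores

The compounds below may be only part of what the source reports. "The series", "measured", "known", "first", "only" and "open" are said of these compounds alone.

In a functional assay on HeLa cells (Homo sapiens) for inhibition, read by sulforhodamine B assay, with a stated time of 48 h (a higher number here means a weaker inhibitor of growth, a lower number a stronger inhibitor of growth), the three measured compounds give the following numbers.

Compound 1 `COC(=O)[C@@]1(C)CCC=C2[C@@H]1CC[C@@H](C)[C@]2(C)Cc1c[nH]c2ccc(F)cc12` gives 3700 nM.
Compound 2 `COC(=O)[C@@]1(C)CCC=C2[C@@H]1CC[C@@H](C)[C@]2(C)Cc1c[nH]c2ccc(OC)cc12` gives 1200 nM.
Compound 3 `COC(=O)[C@@]1(C)CC[C@@H]2C3=C1CC[C@@H](C)[C@]3(C)C[C@@H]1c3cc(F)ccc3N[C@H]21` gives 20000 nM.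

Compound 1 and compound 2 share one core and differ by methoxy in place of fluoro on an aromatic carbon. That change made a 3.1-fold lower number from compound 1 to compound 2 (0.49 log units; beyond the scatter). Compound 3 carries a different core built from the same atoms, joined differently; the difference between the two cores is not broken down here. In this assay compound 3 gives the highest of the three numbers, with compound 1 nearest and compound 2 furthest.

Compound 4 `COC(=O)[C@@]1(C)CC[C@@H]2C3=C1CC[C@@H](C)[C@]3(C)C[C@@H]1c3cc(OC)ccc3N[C@H]21` is not yet measured. It differs from compound 3 by methoxy in place of fluoro on an aromatic carbon. The surroundings of the place are not identical to those in the first pair: here the aromatic ring is part of a fused or bridged system of five rings, there of two rings, so this is the same kind of change rather than the same change.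

The expected step from compound 3 to compound 4 is a 3.1-fold lower number from compound 3 to compound 4 (0.49 log units; beyond the scatter), resting on the earlier step of a 3.1-fold lower number from compound 1 to compound 2 (0.49 log units; beyond the scatter) on the other core. Compound 4 is accordingly estimated at 6500 nM, with a range of 3000 nM to 15000 nM.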

Compound 4, concentration for 50% growth inhibition: 20000 nM
For compound 4 the middle estimate is 3.1-fold (0.49 log units) below the measured one; measured number above the stated range.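

In this assay, methoxy in place of fluoro on an aromatic carbon gives no change at the digits printed from compound 3 to compound 4 (within the scatter), so the step seen on the core of compound 1 does not carry over to the core of compound 3. The same kind of change therefore gives different results on the two cores, and the gap between the two steps is larger than scatter alone would account for: the same change on two cores in this assay, a 3.1-fold lower number (0.49 log units; beyond the scatter) from compound 1 to compound 2 and no change at the digits printed (within the scatter) from compound 3 to compound 4, 3.1-fold (0.49 log units) apart, beyond the scatter of two such steps

This rests on a single pair for each core, so it does not show which difference between the cores separates the two results, nor whether other changes on these cores would diverge in the same way.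

The compounds shown leave open whether a different group on this aromatic carbon, such as chloro, hydroxyl or an amine, would move the number on the core of compound 3. They also leave open how either core would respond if the methyl ester gave way to a carboxylic acid or an amide.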